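Ester in place of amide on the ring carbonyl

This account rests on a few compounds, and the source may have more. Where it says the series, first, only, none or still open, it means among the compounds named here.

Measured so far:
- compound 1 `CCNC(=O)C1=C(C)NC(=O)NC1c1ccco1`: in an assay on membranes from CHO cells for displacement of a labelled ligand from adenosine receptor A1 (Homo sapiens), read by scintillation counting, with a stated time of 60 min, tested at 1 uM (a lower number here means less inhibition, a higher number more inhibition at the concentration tested (going by the name of the read-out)), compound 1 gives 2%
- compound 2 `CCNC(=O)C1=C(C)NC(=O)NC1c1ccsc1`: in this assay compound 2 gives 3%
- compound 3 `CC1=C(c2ncc(C)o2)C(c2ccsc2)NC(=O)N1`: in this assay compound 3 gives 34%

Compound 2 stands second highest of the three numbers; its nearest neighbour is compound 1, and the two values lie within the scatter of each other, as the step of a number 1 percentage points higher from compound 1 to compound 2 (within the scatter) shows. Within the data shown here, the only large step is a number 31 percentage points higher from compound 2 to compound 3 (beyond the scatter), where the ethylcarbamoyl is replaced by a ring group on the double-bonded ring carbon.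

Compound 4 `CCC(C)OC(=O)C1=C(C)NC(=O)NC1c1ccsc1` differs from compound 2 by sec-butoxy in place of ethylamino on a carbonyl carbon. Among the measured compounds shown here, no measured step alters the ethylcarbamoyl in this way: the step from compound 2 to compound 3 replaces the whole group with 5-methyl-1,3-oxazol-2-yl, not an ester, so it bears only loosely on the change. The step from compound 1 to compound 2 touches a different place and bears on it not at all. The carbonyl and the attachment to the double-bonded ring carbon are kept, so in this assay a step of no more than modest size is expected, a number 5 percentage points higher from compound 2 to compound 4 (within the scatter), with the sign uncertain. Compound 4 is therefore estimated at 8%, within 0% to 30%.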

Compound 4, a percentage reported as inhibition, at one concentration (the size of the read-out at that concentration, not a potency): 5%
Beside the measured number, compound 4's estimate is 3 percentage points above it; low and high end bracket the measured number.
By their numbers in this assay, from the lowest: compounds 1, 2 and 4 (each within the scatter of the next); then compound 3.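

In this assay, sec-butoxy in place of ethylamino on a carbonyl carbon gives a number 2 percentage points higher from compound 2 to compound 4 (within the scatter), so exchanging the amide for this ester does not move the number beyond the scatter, even with the amide hydrogen gone and a branched chain in place. Earlier compounds showed only the removal of the whole ethylcarbamoyl group, with a number 31 percentage points higher from compound 2 to compound 3 (beyond the scatter); the ester, which keeps the carbonyl, does not reproduce that step. No measurement at hand explains either result.

Open, from the compounds shown here alone, is whether a carboxylic acid or a methyl ester on the same carbonyl carbon would stay within the scatter of compound 2. Also open, going by these compounds, is whether sec-butoxy behaves the same way with furan-2-yl on the saturated ring carbon.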